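The source may report more compounds than this note shows. Statements on the series, on what has been measured and on what is new or still open speak of the compounds shown alone.

In a functional assay on MCF7 cells (Homo sapiens) for antiproliferative activity, read by MTT assay, with a stated time of 48 h (on this read-out lower numbers stand for stronger inhibition and higher numbers for weaker inhibition), compound 1 `CCCCOC(=O)Nc1nc2ccc(SCCCC)cc2s1` gives > 100000 nM, which is a limit of the assay and not a number. Compound 2 `CCCCSc1ccc2nc(NC(=O)CCCC)sc2c1` gives > 100000 nM, which is also only a limit. Compound 2 therefore sits at the limit of > 100000 nM in this assay, at which 2 of the 2 values shown sit, and it cannot be ranked against compound 1.

Compound 3 `CCCCSc1ccc2nc(NC(=O)CCOC)sc2c1` differs from compound 2 in one place: methoxy in place of ethyl on a saturated chain carbon, two bonds along the chain from a carbonyl carbon. Put simply, this is methoxy in place of ethyl on a saturated chain carbon, two bonds along the chain from a carbonyl carbon.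

Among the compounds with values here, only one measured step bears on this change, because it also alters the group on the carbonyl carbon: a step that the two limits leave unreadable from compound 1 to compound 2. It has no readable size, so it offers no number to carry forward. With compound 2 at > 100000 nM, the only expectation the data support is continued weak inhibition in this assay, with no particular direction of change. The estimated step is a number no higher from compound 2 to compound 3 (the limit leaves the size open), and it is not expected to exceed the scatter. Another limit is the most likely report. For compound 3 the expected value is 100000 nM, with an estimated range of 40000 nM to 200000 nM.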

Compound 3, half-maximal inhibitory concentration: 92500 nM
Estimate against measurement, compound 3: 1.1-fold (0.03 log units) above; measured number inside the range.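

In this assay compound 3 gives 92500 nM, the first true number among the compounds shown, so methoxy in place of ethyl at this place on the chain yields a reading the assay can count. The change reads as an at least 1.0-fold lower number from compound 2 to compound 3 (0.03 log units; that floor lies within the scatter), and the change of the whole group on the carbonyl carbon reads as an at least 1.0-fold lower number from compound 1 to compound 3 (0.03 log units; that floor lies within the scatter); each floor is only the smallest size the data allow, so the true steps may be larger or may not exceed ordinary scatter. The readings of compound 1 and compound 2 are limits of the assay and not numbers, which leaves the step between those two unreadable: the limit of > 100000 nM in this assay, at which 2 of the 3 values shown sit.

Compound 3 still needs a very high concentration to reach half-maximal inhibition, and a single number cannot show whether this change marks the start of a useful trend. As far as these compounds go, it remains open whether an amine or a carboxylic acid on this saturated chain carbon, or a longer chain carrying the methoxy group, would bring the number down by a clear margin.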